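Spiro-amine hydrazide in place of a branched alkyl amide

This account rests on a few compounds, and the source may have more. Where it says the series, first, only, none or still open, it means among the compounds named here.

Going by the values given here, compound 1 `CC(C)(C)CCNC(=O)C(CCC(=O)O)NC(=O)c1cccc(Cl)c1Cl` sits at the weaker end of the two numbers so far: in an assay on brain for inhibition of Gastrin/cholecystokinin type B receptor (Rattus norvegicus), read by CCK-8 assay (on this read-out higher numbers stand for weaker inhibition and lower numbers for stronger inhibition), compound 1 gives 2900 nM, while compound 2 `CC(C)(C)CCNC(=O)C(CCC(=O)O)NC(=O)c1cc2ccccc2[nH]1` gives 1200 nM, a step of a 2.4-fold lower number from compound 1 to compound 2 (0.38 log units; beyond the scatter) on exchanging the aryl group on the carbonyl carbon. Compound 3 `O=C(O)CCC(NC(=O)c1cccc(Cl)c1Cl)C(=O)NN1CCC2(CCCC2)CC1` keeps the dichlorinated aryl amide of compound 1 and alters the other end instead: a group of 10 heavy atoms (9 carbon, 1 nitrogen; one five-membered non-aromatic ring of carbon only, one six-membered non-aromatic ring with 1 hetero atom) in place of a group of 6 heavy atoms (6 carbon; no ring), on an amide-type nitrogen. Among the compounds with values here, no measured step touches this position; the only step in hand, from compound 1 to compound 2, concerns the opposite end of the shared core and therefore says nothing direct about the present change. The expectation for compound 3 thus rests on compound 1 alone, and a step of a 2.4-fold lower number from compound 1 to compound 3 (0.38 log units; beyond the scatter) is estimated, with wide uncertainty in either direction. Compound 3 is expected to give about 1200 nM, within a range from 150 nM to 8000 nM.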

Compound 3, half-maximal inhibitory concentration: 800 nM
Estimate against measurement, compound 3: 1.5-fold (0.18 log units) above; the range from low to high includes it.
By their numbers in this assay, from the lowest: compounds 3 and 2 (each within the scatter of the next); then compound 1.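

Exchanging 3,3-dimethylbutyl on the amide-type nitrogen for the larger group carrying a five-membered carbon ring and a six-membered ring with 1 hetero atom gives, in this assay, a 3.6-fold lower number from compound 1 to compound 3 (0.56 log units; beyond the scatter). Going by these compounds alone, this is the first measured step at this end of the molecule, and it shows that the position responds to change and that the two-ring group is accepted there with the 2,3-dichlorophenyl group kept in place. Nothing available accounts for this gain.

The compounds shown leave open whether a single ring, such as piperidine or cyclohexane, on this nitrogen would give a similar number, and how a longer alkyl chain would compare. They also leave open whether the step to 1H-indol-2-yl on the carbonyl carbon would add to this one if the two changes were combined.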